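Carbamate Aryl Change in a Flat Inhibition Series

The source may hold more compounds than are shown below. What is called first, only, known or untested is meant among the compounds shown, and "the series" means these compounds.

Measured compounds:
compound 1 `CC(C)=CCC/C(C)=C/CC1Cc2c(O)cc(=O)n(CCCO)c2CC1(C)C`: 0%
compound 2 `CC(C)=CCC/C(C)=C/CC1Cc2c(OCCCOc3ccc(Cl)cc3)cc(=O)n(CCCO)c2CC1(C)C`: 0%
compound 3 `CC(C)=CCC/C(C)=C/CC1Cc2c(OC(=O)Nc3cccc(F)c3)cc(=O)n(CCCO)c2CC1(C)C`: 0%

In a functional assay on PANC-1 cells (Homo sapiens) for inhibition, read by MTT assay, with a stated time of 24 h, tested at 10 uM (on this read-out higher numbers stand for more inhibition at the one concentration tested (going by the name of the read-out) and lower numbers for less inhibition), compound 1 gives 0%, and the two compounds built from it on the oxygen on the aromatic ring do no better: no change at the digits printed from compound 1 to compound 2 (within the scatter) and no change at the digits printed from compound 1 to compound 3 (within the scatter). Between the two substituted compounds there is also nothing, no change at the digits printed from compound 2 to compound 3 (within the scatter). Among the compounds with values here, compound 3 therefore stands level with compound 1 and compound 2, with no step reaching beyond the scatter.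

Compound 4 `CC(C)=CCC/C(C)=C/CC1Cc2c(OC(=O)Nc3ccc(F)cc3F)cc(=O)n(CCCO)c2CC1(C)C` carries 2,4-difluorophenyl in place of 3-fluorophenyl on an amide-type nitrogen. Within the data shown here, no measured step touches the aryl ring of the carbamoyl group, so only the three flat steps above bear on it, and they show that neither hydrogen, the 3-(4-chlorophenoxy)propyl group nor the (3-fluorophenyl)carbamoyl group on that oxygen moved this assay at all. On this basis the step of no change at the digits printed from compound 3 to compound 4 (within the scatter) is expected to stay within the scatter. Compound 4 is estimated to give 0% in this assay, between 0% and 10%.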

Compound 4, a percentage reported as inhibition, at one concentration (the size of the read-out at that concentration, not a potency): 15.6%
Estimate against measurement, compound 4: 15.6 percentage points below; the measured number lies above the stated range.
By their numbers in this assay, from the lowest: compounds 1, 2 and 3 (each within the scatter of the next); then compound 4.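

In this assay, within the data shown here, the aryl ring of the carbamate gives the first change to read beyond the scatter: 2,4-difluorophenyl in place of 3-fluorophenyl on the amide-type nitrogen gives a number 15.6 percentage points higher from compound 3 to compound 4 (beyond the scatter). The full (2,4-difluorophenyl)carbamoyl group on the oxygen on the aromatic ring also stands clear of the other two groups there, with a number 15.6 percentage points higher from compound 1 to compound 4 (beyond the scatter) against hydrogen and a number 15.6 percentage points higher from compound 2 to compound 4 (beyond the scatter) against 3-(4-chlorophenoxy)propyl, so this position is not silent in every form, although each step is modest. No evidence is available to explain why this change moves the read-out.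

The compounds shown leave open whether the second fluorine alone accounts for the step, and whether a carbamate aryl ring carrying chlorine or methoxy would do the same. They also leave open how compound 4 behaves at any other concentration.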